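3,5-Dichlorophenyl for 3-ethynylphenyl on two isomeric cores

This account rests on a few compounds, and the source may have more. Where it says the series, first, only, none or still open, it means among the compounds named here.

Measured so far in a functional assay on MCF7 cells (Homo sapiens) for antiproliferative activity, read by MTT assay, with a stated time of 48 h; a higher number here means a weaker inhibitor, a lower number a stronger inhibitor:
compound 1 `C#Cc1cccc(Nc2ncnc3cc(NC(=O)/C=C/c4ccccc4)sc23)c1`: 75600 nM
compound 2 `O=C(/C=C/c1ccccc1)Nc1cc2ncnc(Nc3cc(Cl)cc(Cl)c3)c2s1`: a limit, > 100000 nM
compound 3 `C#Cc1cccc(Nc2ncnc3sc(NC(=O)/C=C/c4ccccc4)cc23)c1`: 38400 nM

Compound 2 reports only a limit of the assay in this assay, not a number. Compound 1 and compound 3 carry the same atoms joined differently; the difference between the two cores is not broken down here. Compound 3 gives the lowest number of the two, and compound 1 sits within the usual scatter of it, so no order is claimed between them.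

Going by the values given here, the one change that is measured is 3,5-dichlorophenyl in place of 3-ethynylphenyl on a nitrogen on an aromatic ring, and it reads an at least 1.3-fold higher number from compound 1 to compound 2 (0.12 log units; that floor lies within the scatter). The floor of that step lies within the scatter, so its true size is open; what is known is that compound 2 reaches the limit, (the limit of > 100000 nM in this assay, at which 1 of the 3 values shown sits).

Compound 4 `O=C(/C=C/c1ccccc1)Nc1cc2c(Nc3cc(Cl)cc(Cl)c3)ncnc2s1` is not yet measured in this assay. It carries the same change on the core of compound 3: 3,5-dichlorophenyl in place of 3-ethynylphenyl on a nitrogen on an aromatic ring. Since the two place lines read alike, this is taken as the same change, only on the other core. Compound 4 is expected to move in the same direction as the measured step of an at least 1.3-fold higher number from compound 1 to compound 2 (0.12 log units; that floor lies within the scatter), by a 2.1-fold higher number from compound 3 to compound 4 (0.32 log units; beyond the scatter), resting on compound 3 at 38400 nM as the start. The estimate for compound 4 is therefore 80000 nM, between 40000 nM and 160000 nM, with a real chance that only the limit is reported because of the limit of > 100000 nM in this assay, at which 1 of the 3 values shown sits.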

Compound 4, half-maximal inhibitory concentration: 5800 nM
Compound 4: middle estimate off by 14-fold (1.14 log units), on the high side; measured number outside the range, below it.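

In this assay, 3,5-dichlorophenyl in place of 3-ethynylphenyl on the core of compound 3 reads a 6.6-fold lower number from compound 3 to compound 4 (0.82 log units; beyond the scatter). Set beside the same change on the core of compound 1, this shows that the change cannot be carried from one of these isomeric cores to the other as a fixed step, and that the core on which it is made matters to the outcome in this pair of pairs: the same change on two cores in this assay, an at least 1.3-fold higher number (0.12 log units; that floor lies within the scatter) from compound 1 to compound 2 and a 6.6-fold lower number (0.82 log units; beyond the scatter) from compound 3 to compound 4, at least 8.7-fold (0.94 log units) apart, beyond the scatter of two such steps

This does not show why the two cores part, nor that either aryl group is the better one in general, as it rests on one pair per core, and the step on the core of compound 1 ends at a limit of the assay, so its true size stays open: the limit of > 100000 nM in this assay, at which 1 of the 4 values shown sits.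

The compounds shown leave open how other groups on the nitrogen would behave on each core, for example a phenyl carrying one chlorine and one ethynyl, or a phenyl carrying methoxy groups, and so whether the split between the cores belongs to this one change alone. Also open, on these data alone, is whether the split holds when the phenyl of the amide side chain carries something else, such as an amine or a carboxylic acid.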